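Replacing the Acyl Chain on the Ring Nitrogen of Compound 3

The compounds below may be only part of what the source reports. "The series", "measured", "known", "first", "only" and "open" are said of these compounds alone.

Compound 1 `Cc1cc(C)c2cccc(OCc3c(Cl)ccc(S(=O)(=O)NC4(C(=O)N5CCN(C(=O)CCCCC[N+](C)(C)C)CC5)CCCC4)c3Cl)c2n1`: in an assay on isolated protein for binding affinity to B1 bradykinin receptor (Homo sapiens) (a lower number here means a stronger inhibitor, a higher number a weaker inhibitor), compound 1 gives < 10000 nM, which is a limit of the assay and not a number.
Compound 2 `Cc1cc(C)c2cccc(OCc3c(Cl)ccc(S(=O)(=O)NC4(C(=O)N5CCN(C(=O)C[C@@H](N)CCCN)CC5)CCCC4)c3Cl)c2n1`: compound 2 gives < 10000 nM, again a limit of the assay.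
Compound 3 `Cc1cc(C)c2cccc(OCc3c(Cl)ccc(S(=O)(=O)NC4(C(=O)N5CCN(C(=O)CCCC[N+](C)(C)C)CC5)CCCC4)c3Cl)c2n1`: compound 3 gives < 10000 nM, again a limit of the assay.

All three measured values sit at the same point, (the limit of < 10000 nM in this assay, at which 3 of the 3 values shown sit), so compound 3 stands nowhere that can be told apart from the other two. The three steps, a step that the two limits leave unreadable from compound 1 to compound 2, a step that the two limits leave unreadable from compound 1 to compound 3 and a step that the two limits leave unreadable from compound 2 to compound 3, are all unreadable; none gives a direction or a size.

Compound 4 `Cc1cc(C)c2cccc(OCc3c(Cl)ccc(S(=O)(=O)NC4(C(=O)N5CCN(C(=N)NCCC[N+](C)(C)C)CC5)CCCC4)c3Cl)c2n1` differs from compound 3 in the chain carried by the ring nitrogen: a group of 10 heavy atoms (7 carbon, 3 nitrogen; no ring) in place of a group of 10 heavy atoms (8 carbon, 1 nitrogen, 1 oxygen; no ring), on an amine nitrogen in a ring. The steps from compound 1 to compound 3 and from compound 2 to compound 3 concern the same region of the molecule, but as both are unreadable they give no expected size or direction for this assay beyond the scatter.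

The most that can be said is that compound 3 was reported only as a limit, and the change to compound 4 is of a kind whose effect the measured steps do not reveal. Compound 4 is therefore expected to give about 5000 nM (range 800 nM to 20000 nM) in this assay, with a high chance of another limit, meaning an expected step that the limit leaves unreadable from compound 3 to compound 4.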

Compound 4, inhibition constant: < 10000 nM
Compound 4: a limit, no number; the forecaster's own chance of this, stated with the estimate: 70%; the middle value lies beyond the limit too.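

In this assay compound 4 gives < 10000 nM, again a limit of the assay and not a number. Its steps to compound 1, compound 2 and compound 3 therefore cannot be read, and all four compounds sit at one point: the limit of < 10000 nM in this assay, at which 4 of the 4 values shown sit.

The compounds shown leave open whether changing the chain on the ring nitrogen alters the value in this assay at all.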